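Swapping Fluoro for Methoxy on the Aromatic Ring

The compounds below may be only part of what the source reports. "The series", "measured", "known", "first", "only" and "open" are said of these compounds alone.

Compound 3, `N=C(NCc1ccccc1)[C@@H]1CCC(=O)N1Cc1ccc(F)cc1`, gives 31.4% in a functional assay on SH-SY5Y cells (Homo sapiens) for cytotoxicity, read by MTT assay, with stated times of 8 h, 30 min and 12 h, tested at 5 uM (on this read-out higher numbers stand for a stronger effect at the one concentration tested and lower numbers for a weaker effect), the highest of the three numbers recorded. Compound 1, `N=C(NCc1ccccc1)[C@@H]1CCC(=O)N1Cc1ccccc1`, gives 20.7%, and compound 2, `N=C(NCc1ccccc1)[C@@H]1CCC(=O)N1Cc1ccc([N+](=O)[O-])cc1`, gives 25.6%. Of the steps among them, only a number 10.7 percentage points higher from compound 1 to compound 3 (beyond the scatter) lies beyond the scatter, while a number 4.9 percentage points higher from compound 1 to compound 2 (within the scatter) and a number 5.8 percentage points higher from compound 2 to compound 3 (within the scatter) lie within it. Compound 4, `COc1ccc(CN2C(=O)CC[C@H]2C(=N)NCc2ccccc2)cc1`, differs from compound 3 by methoxy in place of fluoro on an aromatic carbon. For the measured compounds named here, no measured step exchanges fluoro for methoxy, but the three changes at this same aromatic carbon were all modest or within the scatter, so a small change at most is expected. Compound 4 is therefore estimated at 27%, between 15% and 40%, a step of a number 4.4 percentage points lower from compound 3 to compound 4 (within the scatter) expected to stay within the scatter.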

Compound 4, a percentage reported as activity, at one concentration (the size of the read-out at that concentration, not a potency): 17.9%
For compound 4 the middle estimate is 9.1 percentage points above the measured one, within the range that was stated.
By their numbers in this assay, from the lowest: compounds 4, 1, 2 and 3 (each within the scatter of the next, the first and the last beyond it).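

In this assay, for the compounds shown here, the exchange of fluoro for methoxy gives a number 13.5 percentage points lower from compound 3 to compound 4 (beyond the scatter) and is the first step beyond the scatter between two substituents at this aromatic carbon. Methoxy gives a number 2.8 percentage points lower from compound 1 to compound 4 (within the scatter) against hydrogen and a number 7.7 percentage points lower from compound 2 to compound 4 (within the scatter) against nitro, so of the three substituents shown only fluoro separates from hydrogen. Nothing available accounts for this difference between fluoro and methoxy.

Going by these compounds, whether an amine, a carboxylic acid or a chlorine atom at this carbon would group with fluoro or with methoxy remains open. Also open, on these data alone, is whether the same order holds at other concentrations.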